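Swapping the oxazole on a thiazolyl sulfonamide

The compounds below may be only part of what the source reports. "The series", "measured", "known", "first", "only" and "open" are said of these compounds alone.

Measured in a physicochemical assay for lipophilicity; on this read-out lower numbers stand for lower lipophilicity and higher numbers for higher lipophilicity:
Compound 1 `Cc1nc(-c2cc(C(F)(F)F)ccc2[C@H]2CCOc3cc(S(=O)(=O)Nc4cccc(F)n4)ccc32)co1`: 4
Compound 2 `Cc1nc(-c2cc(C(F)(F)F)ccc2[C@H]2CCOc3cc(S(=O)(=O)Nc4nccs4)ccc32)co1`: 2.9

Of these two, compound 2 holds the lower number, 2.9. Compound 3 `O=C1COCCN1c1cc(C(F)(F)F)ccc1[C@H]1CCOc2cc(S(=O)(=O)Nc3nccs3)ccc21` keeps the core of compound 2 and carries 3-oxomorpholin-4-yl in place of 2-methyl-1,3-oxazol-4-yl on an aromatic carbon. Among the compounds with values here, the only measured step, a number 1.10 log units lower from compound 1 to compound 2 (beyond the scatter), is large, but it lies on a sulfonamide nitrogen, so it bears on this exchange only loosely. Within the data shown here, no measured step covers this exchange itself. A clear move to a lower number is nevertheless expected, with an estimated a number 0.80 log units lower from compound 2 to compound 3 (beyond the scatter). Compound 3 is estimated at 2.1, within an expected range of 1.6 to 2.7.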

Compound 3, distribution coefficient: 1.8
Estimate against measurement, compound 3: 0.30 log units above, and the stated range covers the measured number.
By their numbers in this assay, from the lowest: compound 3; then compound 2; then compound 1.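

In this assay, the aromatic carbon ortho to a large group proved as responsive as the sulfonamide nitrogen: replacing 2-methyl-1,3-oxazol-4-yl with 3-oxomorpholin-4-yl gave a number 1.10 log units lower from compound 2 to compound 3 (beyond the scatter), matching the size of a number 1.10 log units lower from compound 1 to compound 2 (beyond the scatter). The substituent on this carbon can therefore shift the number substantially with the thiazolyl sulfonamide in place. Nothing available explains the size of this shift. On these data alone, it remains open how a plain morpholin-4-yl ring or a simple amine would read at this carbon, and whether 3-oxomorpholin-4-yl would give a similar step alongside the 6-fluoropyridin-2-yl group.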